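Replacing Cyclohexyl With a Pyrrolidinylethyl Chain on the Amide

The source may hold more compounds than are shown below. What is called first, only, known or untested is meant among the compounds shown, and "the series" means these compounds.

In an ADME assay on MRC5 cells (Homo sapiens) for inhibition, with a stated time of 72 h (a higher number here means that more compound is needed for the effect, a lower number that less compound is needed), the measured compounds gave:
Compound 1 `COc1cccc(OC)c1C(=O)Nc1c[nH]nc1C(=O)N[C@H]1CC[C@H](O)CC1`: 34000 nM
Compound 2 `COc1cccc(OC)c1C(=O)Nc1c[nH]nc1C(=O)NCCCN(C)C`: > 50000 nM
Compound 3 `COc1cccc(OC)c1C(=O)Nc1c[nH]nc1C(=O)NC1CCCCC1`: 35000 nM

Compound 3 stands with compound 1 among the two real numbers, and the step of a 1.0-fold higher number from compound 1 to compound 3 (0.01 log units; within the scatter) shows the pair lies within the usual scatter, so no order between them can be read. The value of compound 2 is a limit of the assay and not a number (the limit of > 50000 nM in this assay, at which 1 of the 3 values shown sits).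

Compound 4 `COc1cccc(OC)c1C(=O)Nc1c[nH]nc1C(=O)NCCN1CCCC1` has not yet been measured. It differs from compound 3 in one place: 2-(pyrrolidin-1-yl)ethyl in place of cyclohexyl on an amide-type nitrogen. The step that bears most on this change is an at least 1.4-fold lower number from compound 2 to compound 3 (0.15 log units; that floor lies within the scatter), which runs the opposite way, from a chain carrying a hydrogen-bond acceptor back to a plain carbon ring, and starts from a limit. The step of an at least 1.4-fold higher number from compound 1 to compound 2 (0.16 log units; that floor lies within the scatter) points the same way. Both suggest that exchanging the ring for a chain gives a higher number or reaches the limit, though each floor lies within the scatter.

Compound 4 is therefore expected to give about 50000 nM, between 25000 nM and 100000 nM, with a real chance that only a limit is reported. That estimate means an expected step of a 1.4-fold higher number from compound 3 to compound 4 (0.15 log units; within the scatter) toward a higher number.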

Compound 4, half-maximal effective concentration: > 50000 nM
Compound 4 ended at the assay's limit (the forecaster's own chance of this, stated with the estimate: 55%); the middle value sits exactly at the limit.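

In this assay, compound 4 joins compound 2 at a limit of the assay, which is not a number: the limit of > 50000 nM in this assay, at which 2 of the 4 values shown sit.

Set against the two ring compounds, the result reads an at least 1.4-fold higher number from compound 3 to compound 4 (0.15 log units; that floor lies within the scatter) and an at least 1.4-fold higher number from compound 1 to compound 4 (0.16 log units; that floor lies within the scatter), so the true size of either step stays unknown. Among these four compounds, the two carrying a nitrogen-bearing chain on the amide nitrogen sit at the limit and the two carrying a cyclohexane ring give real numbers, while the step between the two chains cannot be read.

A plain hexyl chain, with no nitrogen in it, could show whether the chain itself or its nitrogen goes with reaching the limit. On these data alone, whether 2-morpholinoethyl or a carboxylic acid at the chain end would give a real number also stays open.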